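This account rests on a few compounds, and the source may have more. Where it says the series, first, only, none or still open, it means among the compounds named here.

Working notes on the series.

The read-out throughout is a functional assay on A549 cells (Homo sapiens) for antiproliferative activity, read by MTT assay, with a stated time of 72 h; on this read-out lower numbers stand for stronger inhibition and higher numbers for weaker inhibition. Compound 1 `COc1cc2c(Oc3ccc(NC(=O)C4(c5nnc(-c6ccc(F)cc6)o5)CC4)cc3F)ccnc2cc1OCCCN1CCCC1` gives 150 nM. Compound 2 `COc1cc2c(Oc3ccc(NC(=O)c4cc(-c5ccc(F)cc5)on4)cc3)ccnc2cc1OCCCN1CCC(C)CC1` gives 3340 nM. Compound 3 `COc1cc2nccc(Oc3ccc(NC(=O)c4ncc(-c5ccc(F)cc5)o4)cc3)c2cc1OC` gives 5590 nM. On these three numbers compound 2 stands second highest: the gap to compound 3 falls within the usual scatter, so the two are not separated, whereas compound 1 sits well apart, its number being beyond the scatter lower than that of compound 2. Compound 1 differs from compound 2 in several places at once, so no single-change step can be read from the pair.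

Compound 4 `COc1cc2c(Oc3ccc(NC(=O)c4nc(-c5ccc(F)cc5)no4)cc3)ccnc2cc1OCCCN1CCC(C)CC1` has not yet been measured in this assay. Its change from compound 2 is 3-(4-fluorophenyl)-1,2,4-oxadiazol-5-yl in place of 5-(4-fluorophenyl)-1,2-oxazol-3-yl on a carbonyl carbon. For the measured compounds named here, no measured pair isolates a change of this kind, and the two five-membered heteroaromatic variations seen elsewhere in the set (compound 1 and compound 3) come with other differences, so they give no direct guide. The expectation is therefore a step of no size beyond the scatter, in either direction, from compound 2 to compound 4, written as a 1.1-fold lower number from compound 2 to compound 4 (0.05 log units; within the scatter). Compound 4 is thus expected to give about 3000 nM in this assay, with a range from 900 nM to 10000 nM.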

Compound 4, half-maximal inhibitory concentration: 870 nM
Compound 4: the middle estimate sits 3.4-fold (0.54 log units) above what was measured; measured number outside the range, below it.
By their numbers in this assay, from the lowest: compound 1; then compound 4; then compounds 2 and 3 (each within the scatter of the next).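

For the compounds shown here, with the rest of the structure unchanged, 3-(4-fluorophenyl)-1,2,4-oxadiazol-5-yl in place of 5-(4-fluorophenyl)-1,2-oxazol-3-yl on a carbonyl carbon whose other neighbour is an amide-type nitrogen gives a 3.8-fold lower number from compound 2 to compound 4 (0.58 log units; beyond the scatter) in this assay, a modest step but one beyond the scatter, and the first single-place comparison. The two groups have the same heavy-atom count and the same six-membered aromatic ring of carbon only, and they differ in the five-membered aromatic ring, which carries one more hetero atom and one more hydrogen-bond acceptor in the entering group, so the read-out at this position responds to the identity of that ring and not only to the presence of a fluorophenyl-bearing heteroaromatic group. Nothing on hand identifies which feature of the exchange accounts for the step.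

From the compounds shown here alone, whether other five-membered rings on this carbonyl carbon, such as a thiazole or a pyrazole, would follow the same direction remains open. Also open, going by these compounds, is whether the step would persist with a morpholine in place of the 4-methylpiperidine at the end of the side chain.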